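Methyl on the benzyl arm: notes toward compound 4

A few compounds are considered here, and "the series" means these few. Any claim that something is new, unique, unknown or untested is made for them only; others in the source may bear on it.

Compound 3 `COc1cc(-c2nc3cc(/C=C4\SC(=O)N(Cc5ccccc5)C4=O)ccc3[nH]2)cc(OC)c1OC` carries a benzyl group on the ring nitrogen of the shared core. Among the measured compounds shown here, in an ADME assay on HEK-293T cells (Homo sapiens) for inhibition, read by MTT assay, with a stated time of 48 h (a higher number here means a weaker inhibitor, a lower number a stronger inhibitor), compound 3 gives 8210 nM, the lowest of the three numbers so far. The unsubstituted parent, compound 1 `COc1cc(-c2nc3cc(/C=C4\SC(=O)NC4=O)ccc3[nH]2)cc(OC)c1OC`, gives in this assay 13600 nM, and the piperidinylcarbonylmethyl analogue, compound 2 `COc1cc(-c2nc3cc(/C=C4\SC(=O)N(CC(=O)N5CCCCC5)C4=O)ccc3[nH]2)cc(OC)c1OC`, gives in this assay 21500 nM. For the measured compounds named here, the steps among them are small: a 1.7-fold lower number from compound 1 to compound 3 (0.22 log units; within the scatter) and a 1.6-fold higher number from compound 1 to compound 2 (0.20 log units; within the scatter) both sit within the scatter, while a 2.6-fold lower number from compound 2 to compound 3 (0.42 log units; beyond the scatter) is the only step that clears it.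

Compound 4 `COc1cc(-c2nc3cc(/C=C4\SC(=O)N(Cc5cccc(C)c5)C4=O)ccc3[nH]2)cc(OC)c1OC` differs from compound 3 by methyl in place of hydrogen on an aromatic carbon: the change reads, one bond further out, benzyl to 3-methylbenzyl, the methyl sitting meta to a large group. Going by the values given here, no measured step changes a substituent on that aromatic ring; the steps that touch the arm at all, from compound 1 to compound 3 and from compound 2 to compound 3, replace the whole arm and still move the number only slightly. With nothing in the series pointing to a shift from a single methyl on the phenyl ring, no step beyond the scatter is expected here, and a 1.1-fold lower number from compound 3 to compound 4 (0.04 log units; within the scatter) is estimated accordingly. Compound 4 is therefore expected to give about 7500 nM in this assay, with a likely range from 3500 nM to 16000 nM.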

Compound 4, half-maximal inhibitory concentration: 18900 nM
Estimate against measurement, compound 4: 2.5-fold (0.40 log units) below, and the stated range ends below it.
By their numbers in this assay, from the lowest: compounds 3, 1, 4 and 2 (each within the scatter of the next, the first and the last beyond it).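

In this assay, among the compounds shown here, the aromatic ring of the benzyl arm proves to be a place that responds: methyl in place of hydrogen gives a 2.3-fold higher number from compound 3 to compound 4 (0.36 log units; beyond the scatter) as a modest step, whereas until now the only step beyond the scatter was an exchange of one whole arm for another. The added methyl also removes the separation that the benzyl arm had from the piperidinylcarbonylmethyl arm, with a 1.1-fold lower number from compound 2 to compound 4 (0.06 log units; within the scatter) as the reading, and the 3-methylbenzyl arm stays close to the bare ring nitrogen, with a 1.4-fold higher number from compound 1 to compound 4 (0.14 log units; within the scatter) as the reading, so an arm on that nitrogen has not yet been shown to move the number clearly away from the parent. No measurement at hand accounts for the step from benzyl to 3-methylbenzyl.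

Open, from the compounds shown here alone, is whether this response belongs to the methyl itself or to any group at that carbon, since a chlorine, a methoxy, a carboxylic acid or an aminomethyl there would test it. Equally open, going by these compounds, is whether a methyl on another carbon of the same ring would give a step of similar size, or one in the opposite direction.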